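The compounds below may be only part of what the source reports. "The series", "measured", "known", "first", "only" and "open" are said of these compounds alone.

Measured so far:
Compound 1, `COCC[C@H]1C[C@@H]1c1cncc(N2C[C@@H]3C[C@H]2CN3)c1`, gives 4810 nM in an assay on a protein complex for displacement of a labelled ligand from Neuronal acetylcholine receptor; alpha2/beta4 (Rattus norvegicus), read by scintillation counting; on this read-out higher numbers stand for weaker inhibition and lower numbers for stronger inhibition.
Compound 2, `COCC[C@H]1C[C@@H]1c1cncc(N2CCCNCC2)c1`, gives 460 nM in this assay.

On these two numbers compound 2 stands lowest; its nearest neighbour is compound 1, whose number is higher by a margin that lies beyond the scatter, so of the two compound 2 is the stronger binder. The step from compound 2 to compound 3, `COCC[C@@H]1C[C@H]1c1cncc(N2CCCNCC2)c1`, leaves the atoms and bonds untouched: the two compounds have the same atoms and bonds and differ only in configuration as drawn: 2 of 2 stereo elements differ (all stereocentres are inverted: mirror images); a stereocentre at a saturated ring carbon is drawn R in compound 2 and S in compound 3; a stereocentre at a saturated ring carbon is drawn S in compound 2 and R in compound 3. In words, the two compounds have the same atoms and bonds and differ only in configuration as drawn; a stereocentre at a saturated ring carbon is drawn R in compound 2 and S in compound 3, and a stereocentre at a saturated ring carbon is drawn S in compound 2 and R in compound 3.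

No measured pair in this set shows what a mirror image does in this assay, so the direction of this step rests on no shown value. Mirror images commonly separate in such assays, and the expectation is a weakening step of a 3.0-fold higher number from compound 2 to compound 3 (0.48 log units; beyond the scatter) for compound 3. Compound 3 is estimated at 1400 nM, in the range 300 nM to 8000 nM.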

Compound 3, inhibition constant: 256 nM
Beside the measured number, compound 3's estimate is 5.5-fold (0.74 log units) above it, and the stated range ends above it.
By their numbers in this assay, from the lowest: compounds 3 and 2 (each within the scatter of the next); then compound 1.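

Among the compounds shown here, compounds 2 and 3 form the first pair in this set that differ in one place, and the difference is purely one of stereochemistry: the fact that compounds 2 and 3 differ only in the configuration as drawn. In this assay, inverting both stereocentres gives a 1.8-fold lower number from compound 2 to compound 3 (0.25 log units; within the scatter), so this pair shows no separation between the mirror images that exceeds the usual scatter of the measurement. For the compounds shown here, at this position, then, the configuration as drawn is the only change tested, and with the seven-membered-ring amine of compounds 2 and 3 held constant, full inversion leaves the binding number indistinguishable within that scatter.

The compounds shown leave open what happens when only one of the two stereocentres is inverted, and whether the mirror-image pair would stay as close with the amine of compound 1 in place of the amine shared by compounds 2 and 3. They also leave open whether the same holds when the side chain of the shared core ends in a hydroxyl group or a primary amine, or is replaced by a longer chain.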